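Changing the para substituent: from oxadiazole to oxazolyl carbonyl

A few compounds are considered here, and "the series" means these few. Any claim that something is new, unique, unknown or untested is made for them only; others in the source may bear on it.

Among the three measured compounds, compound 3 `CCCCOC(=O)NS(=O)(=O)c1sc(CC(C)C)cc1-c1ccc(Cc2nnc(C(F)(F)F)o2)cc1` stands highest in an assay on membranes from uterus for displacement of a labelled ligand from Angiotensin type II receptor (Sus scrofa), with a stated time of 1.5 h (on this read-out higher numbers stand for weaker inhibition and lower numbers for stronger inhibition), with compound 3 at 328 nM. Compound 1 `CCCCOC(=O)NS(=O)(=O)c1sc(CC(C)C)cc1-c1ccc(Cn2cnc(C(F)(F)F)c2)cc1` gives 7.3 nM and compound 2 `CCCCOC(=O)NS(=O)(=O)c1sc(CC(C)C)cc1-c1ccc(CN2CCCC2=O)cc1` gives 3.5 nM in this assay. Compound 4 `CCCCOC(=O)NS(=O)(=O)c1sc(CC(C)C)cc1-c1ccc(C(=O)c2ncco2)cc1` differs from compound 3 by a group of 7 heavy atoms (4 carbon, 1 nitrogen, 2 oxygen; one five-membered aromatic ring with 2 hetero atoms) in place of a group of 10 heavy atoms (4 carbon, 2 nitrogen, 1 oxygen, 3 fluorine; one five-membered aromatic ring with 3 hetero atoms), on an aromatic carbon. For the measured compounds named here, the steps that bear on this position are large: a 45-fold higher number from compound 1 to compound 3 (1.65 log units; beyond the scatter) and a 94-fold higher number from compound 2 to compound 3 (1.97 log units; beyond the scatter), both showing that the group leaving compound 3 goes with the weakest inhibition seen. Because compound 3 sits at 328 nM while the other two para groups sit far lower, the author expects the new group to bring the number down again, a 13-fold lower number from compound 3 to compound 4 (1.12 log units; beyond the scatter). Compound 4 is therefore estimated at 25 nM, within 4 nM to 150 nM.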

Compound 4, inhibition constant: 13.8 nM
Estimate against measurement, compound 4: 1.8-fold (0.26 log units) above; measured number inside the range.
By their numbers in this assay, from the lowest: compound 2; then compounds 1 and 4 (each within the scatter of the next); then compound 3.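

In this assay, a (1,3-oxazol-2-yl)carbonyl group on this aromatic carbon gives a 24-fold lower number from compound 3 to compound 4 (1.38 log units; beyond the scatter), so the weak binding of compound 3 is not shared by every five-membered aromatic ring placed here. This group has no saturated chain carbon, yet the comparison with the imidazole shows a 1.9-fold higher number from compound 1 to compound 4 (0.28 log units; within the scatter), while the lactam retains a modest edge, with a 3.9-fold higher number from compound 2 to compound 4 (0.60 log units; beyond the scatter). On these data alone, it remains open whether the carbonyl or the oxazole accounts for the change, and what an amine or a carboxylic acid would give here. No supporting measurement explains these steps.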